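Two Measured Thioethers and a Propargyl Question

The source may hold more compounds than are shown below. What is called first, only, known or untested is meant among the compounds shown, and "the series" means these compounds.

Compound 1 `CCOC(=O)C(C)(C)Sc1nc2cc(-n3nc(C(C)(C)C)sc3=O)c(Br)cc2s1`: in an assay on isolated protein for inhibition of protoporphyrinogen oxidase (Homo sapiens), read by capillary electrophoresis (on this read-out lower numbers stand for stronger inhibition and higher numbers for weaker inhibition), compound 1 gives 43500 nM
Compound 2 `CCOC(=O)CCSc1nc2cc(-n3nc(C(C)(C)C)sc3=O)c(Br)cc2s1`: in this assay compound 2 gives 27500 nM

For the measured compounds named here, compound 2 holds the lowest of the two numbers so far, yet its nearest neighbour is compound 1, and the move a 1.6-fold lower number from compound 1 to compound 2 (0.20 log units; within the scatter) is within the scatter, so the two cannot be ranked against each other.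

Compound 3 `C#CCSc1nc2cc(-n3nc(C(C)(C)C)sc3=O)c(Br)cc2s1` has not been measured. It differs from compound 2 by ethynyl in place of (ethoxycarbonyl)methyl on a saturated chain carbon bound to a sulfur; cut one bond further out, the change reads 2-(ethoxycarbonyl)ethyl to propargyl on the sulfur.

Going by the values given here, only one measured step bears on this, the exchange of one ester-bearing chain for another from compound 1 to compound 2, and it stayed within the scatter. Among the compounds with values here, no measured step removes the ester altogether, so the direction of the present change is unsupported by the data. The expectation is therefore a step of a 1.0-fold lower number from compound 2 to compound 3 (0.01 log units; within the scatter) in this assay, with no change beyond the scatter. Compound 3 is estimated at 27000 nM, in a range from 8000 nM to 90000 nM.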

Compound 3, inhibition constant: 20700 nM
The estimate for compound 3 lay 1.3-fold (0.12 log units) above the measured number; measured number inside the range.
By their numbers in this assay, from the lowest: compounds 3, 2 and 1 (each within the scatter of the next, the first and the last beyond it).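

In this assay the ester is not required at this position: ethynyl in place of (ethoxycarbonyl)methyl on a saturated chain carbon bound to a sulfur gives a 1.3-fold lower number from compound 2 to compound 3 (0.12 log units; within the scatter) and so leaves the number within the scatter, even though both hydrogen-bond acceptors of that group leave with it. Propargyl in place of 1-(ethoxycarbonyl)-1-methylethyl on a sulfur gives a 2.1-fold lower number from compound 1 to compound 3 (0.32 log units; beyond the scatter) and is the first step in this short series to pass beyond the scatter, though only modestly, while compound 2 cannot be separated from either of the other two. Nothing available on these compounds accounts for either step.

The compounds shown leave open whether any group on this sulfur can move the number by more than this modest margin, for example a carboxylic acid in place of the ethyl ester, an amine at the end of the chain, or a longer unbranched alkyl chain. They also leave open whether the triple bond of propargyl matters, which a plain propyl group on the sulfur would address.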